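The compounds below may be only part of what the source reports. "The series", "measured", "known", "first", "only" and "open" are said of these compounds alone.

Compound 1 `CCCn1c(=O)[nH]c2nc(-c3ccc(S(=O)(=O)N4CCN(c5ccccc5C)CC4)cc3)[nH]c2c1=O` gives 25% in an assay on CHO cells for displacement of a labelled ligand from adenosine receptor A3 (Homo sapiens), read by scintillation counting, with a stated time of 45 min, tested at 1 uM, in the presence of a further agent that is not named here; on this read-out higher numbers stand for more inhibition at the one concentration tested (going by the name of the read-out) and lower numbers for less inhibition. Compound 2 `CCCn1c(=O)[nH]c2nc(-c3ccc(S(=O)(=O)N4CCN(c5ccccc5F)CC4)cc3)[nH]c2c1=O` gives 9%. Compound 3 `CCCn1c(=O)[nH]c2nc(-c3ccc(S(=O)(=O)N4CCN(c5ccccc5)C(C)C4)cc3)[nH]c2c1=O` gives -2%.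

Compound 1 gives the highest number of the three, with compound 2 nearest and compound 3 furthest below it. Compound 4 `CCCn1c(=O)[nH]c2nc(-c3ccc(S(=O)(=O)N4CCN(C(C)c5ccccc5)CC4)cc3)[nH]c2c1=O` differs from compound 1 by 1-phenylethyl in place of 2-methylphenyl on an amine nitrogen in a ring. Among the compounds with values here, the only measured step, a number 16 percentage points lower from compound 1 to compound 2 (beyond the scatter), alters the aromatic ring on that same ring nitrogen rather than replacing it, so it bears on the change only loosely; compound 3 alters the six-membered ring itself and has no step to compound 1. Both changes away from compound 1 lowered the number, so a modest drop is expected, a number 15 percentage points lower from compound 1 to compound 4 (beyond the scatter). Compound 4 is therefore estimated at 10%, in the range -5% to 25%.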

Compound 4, a percentage reported as inhibition, at one concentration (the size of the read-out at that concentration, not a potency): 0%
Compound 4: the middle estimate sits 10 percentage points above what was measured; the measured number falls inside the stated range.
By their numbers in this assay, from the lowest: compounds 3, 4 and 2 (each within the scatter of the next, the first and the last beyond it); then compound 1.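

Putting 1-phenylethyl in place of 2-methylphenyl on the amine nitrogen in the ring gives a number 25 percentage points lower from compound 1 to compound 4 (beyond the scatter) in this assay, so the larger group, with one more carbon, brings no gain at this position. Against 2-fluorophenyl, the same group gives a number 9 percentage points lower from compound 2 to compound 4 (within the scatter), so compound 2 and compound 4 cannot be told apart here, while compound 1 stands above both. Nothing shown here accounts for these numbers.

Still open, going by these compounds, is how a plain benzyl group or a longer 2-phenylethyl chain on that nitrogen would read.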